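A few compounds are considered here, and "the series" means these few. Any claim that something is new, unique, unknown or untested is made for them only; others in the source may bear on it.

Compound 1 `C#Cc1cccc(/N=C(/NNc2ccccc2C)C(C)=O)c1`: 62 nM
Compound 2 `CC(=O)/C(=N\c1cccc(C(F)(F)F)c1)NNc1ccccc1C`: 291 nM

Both compounds were tested in an assay on isolated protein for binding affinity to corticotropin-releasing factor receptor 1 (Homo sapiens); a higher number here means a weaker inhibitor, a lower number a stronger inhibitor. Compound 1 gives 62 nM, the lowest of the two numbers shown, and compound 2 gives 291 nM. Among the measured compounds shown here, the only measured step, a 4.7-fold higher number from compound 1 to compound 2 (0.67 log units; beyond the scatter), comes from exchanging ethynyl for trifluoromethyl on an aromatic carbon of one ring.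

Compound 3 `C#Cc1cccc(/N=C(/NNc2ccccc2C(F)(F)F)C(C)=O)c1` differs from compound 1 in a different place: trifluoromethyl in place of methyl on an aromatic carbon. For the measured compounds named here, no measured pair exchanges methyl for trifluoromethyl, so the step to compound 2 bears on this change only loosely; it shows that bringing in trifluoromethyl on an aromatic ring, there in place of ethynyl, shifted this assay by a modest amount. A step of similar, modest size is expected here as well, with its direction uncertain and a slightly higher number the more likely outcome, so that the expected step is a 1.9-fold higher number from compound 1 to compound 3 (0.29 log units; within the scatter). Compound 3 is therefore estimated at 120 nM, within a range from 40 nM to 400 nM.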

Compound 3, inhibition constant: 66 nM
For compound 3 the middle estimate is 1.8-fold (0.26 log units) above the measured one; the range from low to high includes it.
By their numbers in this assay, from the lowest: compounds 1 and 3 (each within the scatter of the next); then compound 2.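

In this assay, the exchange of methyl for trifluoromethyl on this aromatic carbon, ortho to a large group, gives a 1.1-fold higher number from compound 1 to compound 3 (0.03 log units; within the scatter), so the two compounds cannot be told apart even though the entering group has 4 heavy atoms where the leaving group has 1. This place on the core of compound 1 therefore accepts either group with no measurable difference in this assay, which the earlier step on the other ring, a 4.7-fold higher number from compound 1 to compound 2 (0.67 log units; beyond the scatter), could not show; that step also replaced a different group, so the two steps are not a direct comparison.

On these data alone, it remains open how a methoxy group, an amine or a longer chain such as ethyl would fare at this same place. The compounds shown also leave open what this ring gives with no group at this place at all, and nothing measured here offers an explanation for the result.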